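Triazole aryl variation: cyano for hydroxymethyl

This account rests on a few compounds, and the source may have more. Where it says the series, first, only, none or still open, it means among the compounds named here.

Going by the values given here, compound 3 `COc1ccc(/C=C\C(=O)O)c(OCc2cn(-c3ccc(CO)cc3)nn2)c1CC=C(C)C` gives 27100 nM in a functional assay on NCI-H322 cells (Homo sapiens) for cytotoxicity, read by MTT assay, with a stated time of 24 h (a lower number here means a stronger inhibitor, a higher number a weaker inhibitor), one of only two numbers obtained so far; compound 1 `COc1ccc(/C=C\C(=O)O)c(OCc2cn(-c3cccc(C#N)c3)nn2)c1CC=C(C)C` gives 26500 nM, within the scatter of compound 3. For compound 2 `COc1ccc(-n2cc(COc3c(/C=C\C(=O)O)ccc(OC)c3CC=C(C)C)nn2)cc1` the result in this assay is "not determined" (no result reported). Compound 4 `COc1ccc(/C=C\C(=O)O)c(OCc2cn(-c3ccc(C#N)cc3)nn2)c1CC=C(C)C` differs from compound 3 by cyano in place of hydroxymethyl on an aromatic carbon. Among the compounds with values here, the single measured step that touches this aryl substituent, a 1.0-fold higher number from compound 1 to compound 3 (0.01 log units; within the scatter), exchanged a cyano for a hydroxymethyl group on the same ring and stayed within the scatter. On that basis the exchange in compound 4 is expected to produce no step beyond the scatter in this assay, a 1.0-fold lower number from compound 3 to compound 4 (0.00 log units; within the scatter). Compound 4 is accordingly estimated at 27000 nM, with a range of 13000 nM to 55000 nM.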

Compound 4, half-maximal inhibitory concentration: 18600 nM
Compound 4: the middle estimate sits 1.5-fold (0.16 log units) above what was measured; the range from low to high includes it.
By their numbers in this assay, from the lowest: compounds 4, 1 and 3 (each within the scatter of the next).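

On the 4-substituted ring, cyano and hydroxymethyl can now be compared directly at the same place: the exchange gives a 1.5-fold lower number from compound 3 to compound 4 (0.16 log units; within the scatter) in this assay. Keeping the cyano group and changing only its ring position gives a 1.4-fold lower number from compound 1 to compound 4 (0.15 log units; within the scatter), so 3-cyanophenyl and 4-cyanophenyl are not separated either. No supporting data bear on these results.

Going by these compounds, whether an amine or a longer chain at this place on the ring would give a step beyond the scatter remains open.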